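The source may report more compounds than this note shows. Statements on the series, on what has been measured and on what is new or still open speak of the compounds shown alone.

Three compounds share one core and differ only in the group carried on a saturated chain carbon bound to a nitrogen on an aromatic ring. Compound 1 `OC[C@H]1O[C@@H](n2cnc3c(NCc4ccccc4F)ncnc32)[C@H](O)[C@@H]1O` has no result in a functional assay on G-361 cells (Homo sapiens) for antiproliferative activity, with a stated time of 72 h (a lower number here means a stronger inhibitor, a higher number a weaker inhibitor), and gives "not determined" (no result reported). Compound 2 `Cc1cccc(CNc2ncnc3c2ncn3[C@@H]2O[C@H](CO)[C@@H](O)[C@H]2O)c1` gives > 166000 nM in this assay, and this is a limit of the assay rather than a number. Compound 3 `OC[C@H]1O[C@@H](n2cnc3c(NCc4ccc(Cl)c(Cl)c4)ncnc32)[C@H](O)[C@@H]1O` gives 145000 nM in this assay. The step of an at least 1.1-fold lower number from compound 2 to compound 3 (0.05 log units; that floor lies within the scatter) is anchored on one side by the limit of > 166000 nM in this assay, at which 1 of the 3 values shown sits, so it can be read only as a floor, and that floor lies within the scatter. On the numbers shown, compound 2 therefore stands only as a limit, with nothing more exact to place it. Compound 4 `OC[C@H]1O[C@@H](n2cnc3c(NCc4ccc(C(F)(F)F)cc4)ncnc32)[C@H](O)[C@@H]1O` is not yet measured; it differs from compound 2 by 4-(trifluoromethyl)phenyl in place of 3-methylphenyl on a saturated chain carbon bound to a nitrogen on an aromatic ring. For the measured compounds named here, the only measured step that bears on this change is an at least 1.1-fold lower number from compound 2 to compound 3 (0.05 log units; that floor lies within the scatter), which exchanges the group on the same carbon and shifts the number by no more than the scatter. Compound 4 is therefore expected to give about 150000 nM in this assay, somewhere between 60000 nM and 400000 nM. That means an expected step of an at least 1.1-fold lower number from compound 2 to compound 4 (0.04 log units; that floor lies within the scatter), not beyond the scatter, with a fair chance that only a limit is reported again.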

Compound 4, half-maximal inhibitory concentration: > 166000 nM
Compound 4 ended at the assay's limit; the forecaster's own chance of this, stated with the estimate: 50%; at least 1.1-fold (0.04 log units) between middle value and limit.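

In this assay compound 4 gives > 166000 nM, a limit of the assay and not a number, so 4-(trifluoromethyl)phenyl on this carbon ends at the same limit as 3-methylphenyl, even though it has more heavy atoms and carries fluorine. For the compounds shown here, the only new step that can be read is an at least 1.1-fold higher number from compound 3 to compound 4 (0.05 log units; that floor lies within the scatter), so the exchange of 3,4-dichlorophenyl for 4-(trifluoromethyl)phenyl cannot be told apart from no change at all. The step with a limit at both ends cannot be read, and the limits among the values leave little room to rank these groups: the limit of > 166000 nM in this assay, at which 2 of the 4 values shown sit.

The compounds shown leave open whether any group at this place can move the number clearly beyond the scatter, as every readable step so far stays within it. They also do not show how a phenyl ring carrying an amine or a carboxylic acid, or a longer chain on this carbon, would read in this assay.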